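Replacing ethynyl with chloro on compound 3

The compounds below may be only part of what the source reports. "The series", "measured", "known", "first", "only" and "open" are said of these compounds alone.

Compound 1 (`COc1cc2nc(Cl)nc(Nc3ccc(O)c(C)c3)c2cc1OC`) gives > 40000 nM in a functional assay on SK-HEP1 cells (Homo sapiens) for cytotoxicity, read by MTT assay, with a stated time of 48 h (a higher number here means a weaker inhibitor, a lower number a stronger inhibitor), which is a limit of the assay and not a number. Compound 2 (`COc1cc2nc(Cl)nc(Nc3cccc(Oc4ccc(C#N)cc4)c3)c2cc1OC`) gives > 40000 nM in this assay, again a limit. Compound 3 (`C#Cc1cccc(Nc2ccnc(Cl)n2)c1`) gives > 40000 nM in this assay, also a limit. Compound 3 therefore has no number of its own, and the series stands at the limit of > 40000 nM in this assay, at which 3 of the 3 values shown sit.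

Compound 4 (`Clc1cccc(Nc2ccnc(Cl)n2)c1`) carries chloro in place of ethynyl on an aromatic carbon. Among the measured compounds shown here, the data contain no step between measured compounds by which to size this change. No shift beyond the usual scatter is expected in this assay, and compound 4 is expected to read at the same limit. This expectation rests on compound 3 and the other two compounds, which all sit at the limit of > 40000 nM in this assay, at which 3 of the 3 values shown sit. The estimated change is a step that the limit leaves unreadable from compound 3 to compound 4, expected to stay within the usual scatter. The estimate for compound 4 is 45000 nM, with an expected range of 20000 nM to 90000 nM.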

Compound 4, half-maximal inhibitory concentration: > 40000 nM
Compound 4: a limit, no number; the forecaster's own chance of this, stated with the estimate: 85%; the middle value lies beyond the limit too.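

In this assay compound 4 gives > 40000 nM, a limit and not a number. Among the compounds shown here, with compound 3 also at a limit, no step from compound 3 to compound 4 can be read. The compounds shown leave open whether any structural change here shifts the read-out, with all values at one limit: the limit of > 40000 nM in this assay, at which 4 of the 4 values shown sit.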